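Hydroxyguanidine hydrazones: dimethylamino replacing chloro on the aryl ring

The source may hold more compounds than are shown below. What is called first, only, known or untested is meant among the compounds shown, and "the series" means these compounds.

Two compounds of the series carry results in a functional assay on HL-60 cells (Homo sapiens) for antiproliferative activity; on this read-out lower numbers stand for stronger inhibition and higher numbers for weaker inhibition. Compound 1 `N=C(NO)N/N=C/c1ccccc1Cl` gives 60000 nM. Compound 2 `N=C(NO)N/N=C/c1ccc(Cl)cc1` reaches only the limit of > 100000 nM, so for compound 2 there is a limit and no number. the limit of > 100000 nM in this assay, at which 1 of the 2 values shown sits, marks the upper edge of what the assay reports, and compound 2 sits at that edge. Going by the values given here, no two measured compounds differ in a single place, so no measured step exists to lean on. Compound 3 `CN(C)c1ccc(/C=N/NC(=N)NO)cc1` differs from compound 2 by dimethylamino in place of chloro on an aromatic carbon. Among the compounds with values here, with only a limit for compound 2 and no comparable measured step, the change from compound 2 to compound 3 is expected to be small, likely within the scatter or at most a modest gain: an at least 1.2-fold lower number from compound 2 to compound 3 (0.09 log units; that floor lies within the scatter). Compound 3 is therefore estimated at 80000 nM in this assay. The expected range for compound 3 runs from 20000 nM to 200000 nM, with a fair chance that again only a limit is reported.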

Compound 3, half-maximal inhibitory concentration: > 100000 nM
Compound 3: a limit, no number; the forecaster's own chance of this, stated with the estimate: 50%; at least 1.2-fold (0.09 log units) between middle value and limit.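

In this assay compound 2 and compound 3 both return only a limit and no number, so no step between them can be read: the limit of > 100000 nM in this assay, at which 2 of the 3 values shown sit.

On these data alone, whether dimethylamino in place of chloro on an aromatic carbon shifts this read-out in either direction remains open.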